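Lengthening the alkyl chain on a quinoline-isoxazole core

The compounds below may be only part of what the source reports. "The series", "measured", "known", "first", "only" and "open" are said of these compounds alone.

Measured so far:
- Compound 1, `CCCCc1cc2ccccc2nc1-c1cc(-c2ccccc2)no1`: > 100000 nM
- Compound 2, `CCc1cc2ccccc2nc1-c1cc(-c2ccc(F)cc2)no1`: > 100000 nM
- Compound 3, `CCCc1cc2ccccc2nc1-c1cc(-c2ccc(F)cc2)no1`: 51300 nM

All three were tested in a functional assay on A549 cells (Homo sapiens) for inhibition, read by MTT assay, with a stated time of 24 h; on this read-out higher numbers stand for weaker inhibition and lower numbers for stronger inhibition. For compound 1 the value > 100000 nM is a limit of the assay, not a number. For compound 2 the value > 100000 nM is likewise a limit. Among the measured compounds shown here, compound 3 is the only compound of the three with a measured number, 51300 nM, so it stands alone as the one point from which a step can be judged.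

The next compound, compound 4 `CCCCc1cc2ccccc2nc1-c1cc(-c2ccc(F)cc2)no1`, differs from compound 3 by methyl in place of hydrogen on a saturated chain carbon, three bonds along the chain from an aromatic carbon. For the measured compounds named here, the only measured step of the same kind runs an at least 1.9-fold lower number from compound 2 to compound 3 (0.28 log units; that floor lies within the scatter); its floor sits within the scatter, so it gives no firm direction. Compound 1, which also carries a butyl chain, sits at the limit of > 100000 nM in this assay, at which 2 of the 3 values shown sit, and two of the three values shown stop there.

Taken together, the step from compound 3 to compound 4 is expected to be small, a 1.2-fold higher number from compound 3 to compound 4 (0.07 log units; within the scatter), with a real chance that only a limit is reported. For compound 4 the estimate in this assay is 60000 nM, within a range from 25000 nM to 150000 nM.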

Compound 4, half-maximal inhibitory concentration: 27500 nM
For compound 4 the middle estimate is 2.2-fold (0.34 log units) above the measured one; the measured number falls inside the stated range.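

Adding this methyl, three bonds along the chain from an aromatic carbon, turns propyl into butyl and gives a 1.9-fold lower number from compound 3 to compound 4 (0.27 log units; within the scatter), so in this assay this single added carbon does not clearly separate the two compounds. Among the compounds shown here, the larger change, ethyl in place of hydrogen two bonds along the chain from an aromatic carbon, gives an at least 3.6-fold lower number from compound 2 to compound 4 (0.56 log units; beyond the scatter), which is the first chain change here to clear the scatter and shows that the butyl chain differs from the shorter ethyl chain. With the butyl chain held the same, fluoro in place of hydrogen on an aromatic carbon gives an at least 3.6-fold lower number from compound 1 to compound 4 (0.56 log units; beyond the scatter), and the true sizes of this step and the previous one remain unknown because each starts from a compound with no measured number: the limit of > 100000 nM in this assay, at which 2 of the 4 values shown sit.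

The compounds shown leave open whether a longer chain, such as hexyl, would bring the number lower still, or whether a chain carrying an amine would behave like the plain butyl chain. They also leave open whether chloro in place of fluoro would give a similar step.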